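A Fluorine Added to a Compound at the Assay Limit

The source may report more compounds than this note shows. Statements on the series, on what has been measured and on what is new or still open speak of the compounds shown alone.

The measured compounds:
compound 1, `COc1cc(/C=C/C(=O)c2sc(Nc3ccc(Cl)c(Cl)c3)nc2C)cc(OC)c1OC`, in a functional assay on NCI-H460 cells (Homo sapiens) for cytotoxicity, read by MTT assay (a lower number here means a stronger inhibitor, a higher number a weaker inhibitor), gives > 25000 nM, a limit of the assay rather than a number.
compound 2, `COc1cc(/C=C/C(=O)c2sc(Nc3cccc(C)c3)nc2C)cc(OC)c1OC`, gives 19800 nM.
compound 3, `COc1cc(/C=C/C(=O)c2sc(Nc3cccc(Cl)c3)nc2C)cc(OC)c1OC`, gives > 25000 nM, again a limit and not a number.

Compound 3 therefore stands at the edge of what this assay can report, and (the limit of > 25000 nM in this assay, at which 2 of the 3 values shown sit). Compound 4, `COc1cc(/C=C/C(=O)c2sc(Nc3ccc(F)c(Cl)c3)nc2C)cc(OC)c1OC`, differs from compound 3 by fluoro in place of hydrogen on an aromatic carbon. The measured steps that bear on this carbon are a step that the two limits leave unreadable from compound 1 to compound 3 and, one bond away in the phenyl ring, an at least 1.2-fold higher number from compound 2 to compound 3 (0.10 log units; that floor lies within the scatter) and an at least 1.2-fold lower number from compound 1 to compound 2 (0.10 log units; that floor lies within the scatter). With compound 1 and compound 3 both sitting at the limit, the step that the two limits leave unreadable from compound 1 to compound 3 shows that swapping chloro for hydrogen at this carbon gives no readable movement, so putting fluoro there is expected to change little. The step from compound 3 to compound 4 is expected to be a step that the limit leaves unreadable from compound 3 to compound 4. Compound 4 is estimated at 28000 nM, within 14000 nM to 60000 nM, and most likely reported only as a limit.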

Compound 4, half-maximal inhibitory concentration: 6310 nM
The estimate for compound 4 lay 4.4-fold (0.65 log units) above the measured number; measured number outside the range, below it.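

In this assay the carbon that carries the new fluoro proves able to move the number: fluoro in place of hydrogen gives an at least 3.9-fold lower number from compound 3 to compound 4 (0.59 log units; beyond the scatter) and fluoro in place of chloro gives an at least 3.9-fold lower number from compound 1 to compound 4 (0.59 log units; beyond the scatter) so the choice of group at this carbon matters. Replacing 3-methylphenyl with 3-chloro-4-fluorophenyl gives a 3.1-fold lower number from compound 2 to compound 4 (0.50 log units; beyond the scatter) but that swap alters the ring at more than one carbon and cannot be credited to fluoro alone. The earlier comparison at this carbon could show none of this, because compound 1 and compound 3 both give only a limit: the limit of > 25000 nM in this assay, at which 2 of the 4 values shown sit.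

On these data alone, whether an amine or a nitrile at this carbon would lower the number as well stays open. As far as these compounds go, how far compound 1 and compound 3 lie beyond their limits is also unknown, so the full size of the steps from them remains open.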